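Cytotoxicity of a Hydroxy Analogue in Place of a Nitro Group

A few compounds are considered here, and "the series" means these few. Any claim that something is new, unique, unknown or untested is made for them only; others in the source may bear on it.

Measured compounds:
compound 1, `Cc1cc(-c2cccc(O)c2)c2ncc(CSCCc3ccccc3)n2c1`, 20 ug/mL
compound 2, `Cc1cc(-c2ccccc2)c2ncc(CSCCc3ccccc3)n2c1`, 20 ug/mL
compound 3, `Cc1cc(-c2cccc([N+](=O)[O-])c2)cn2c(CSCCc3ccccc3)cnc12`, >= 100 ug/mL

Of the compounds shown here, three have been tested in an ADME assay on HEL cells (Homo sapiens) for cytotoxicity, with a stated time of 3 days; on this read-out lower numbers stand for higher toxicity in this test and higher numbers for lower toxicity in this test. Compound 1 `Cc1cc(-c2cccc(O)c2)c2ncc(CSCCc3ccccc3)n2c1` gives 20 ug/mL in this assay. Compound 2 `Cc1cc(-c2ccccc2)c2ncc(CSCCc3ccccc3)n2c1` gives 20 ug/mL in this assay. The step of no change at the digits printed from compound 1 to compound 2 (within the scatter) shows that removing the hydroxy group leaves the read-out unchanged. Compound 3 `Cc1cc(-c2cccc([N+](=O)[O-])c2)cn2c(CSCCc3ccccc3)cnc12` reaches only a limit of the assay, >= 100 ug/mL, so no number is known for it; it sits at the limit of >= 100 ug/mL in this assay, at which 1 of the 3 values shown sits.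

The unmeasured compound 4 `Cc1cc(-c2cccc(O)c2)cn2c(CSCCc3ccccc3)cnc12` differs from compound 3 by the change (hydroxy in place of nitro on an aromatic carbon).

Going by the values given here, no measured step covers this exact change: the only measured step, from compound 1 to compound 2, swaps hydroxy for hydrogen on a different core and shows nothing beyond the scatter. Compound 3 itself offers only a limit, so the starting point is not pinned down. Two measured compounds carry the hydroxy or unsubstituted phenyl and sit well below compound 3's limit, so compound 4 is expected to land between them, giving a step of an at least 2.0-fold lower number from compound 3 to compound 4 (0.30 log units; that floor lies within the scatter). Compound 4 is therefore estimated at 50 ug/mL, within 20 ug/mL to 100 ug/mL.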

Compound 4, minimum cytotoxic concentration: 20 ug/mL
For compound 4 the middle estimate is 2.5-fold (0.40 log units) above the measured one, within the range that was stated.
By their numbers in this assay, from the lowest: compounds 1, 2 and 4 (each within the scatter of the next). At a limit, above all of these: compound 3.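

In this assay, exchanging 3-nitrophenyl for 3-hydroxyphenyl gives an at least 5.0-fold lower number from compound 3 to compound 4 (0.69 log units; beyond the scatter), so on this core the group at this place on the aromatic ring can shift the read-out towards higher toxicity in this test. The earlier pair showed only no change at the digits printed from compound 1 to compound 2 (within the scatter), on a different core and with hydroxy and hydrogen as the two groups, so it gave no sign that a change at this place could move the read-out at all. The full size of the new step stays unknown, since compound 3 gives a limit and not a number: the limit of >= 100 ug/mL in this assay, at which 1 of the 4 values shown sits.

Still open, as far as these compounds go, is whether the step reflects the loss of nitro or the arrival of hydroxy, a question that a plain phenyl on this same core could help to settle. Also open, from the compounds shown here alone, is whether an amine or a methoxy group at this place would stay at the limit or give a lower number, and whether nitro on the core of compound 1 would shift the read-out in the same way.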